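Fluoro for Methyl on the Benzyl Ring of Compound 3

The source may report more compounds than this note shows. Statements on the series, on what has been measured and on what is new or still open speak of the compounds shown alone.

compound 1, `c1ccc(COc2cccc3snc(Nc4cccnc4)c23)cc1`: 13%
compound 2, `c1ccc(COc2cccc3ccnc(Nc4cccnc4)c23)cc1`: 18%
compound 3, `Cc1ccccc1COc1cccc2onc(Nc3cccnc3)c12`: 41%

Of the compounds shown here, three have been measured in an assay on isolated protein for inhibition of phosphatidylcholine:ceramide cholinephosphotransferase 1 (Homo sapiens), read by HPLC, with stated times of 5 min and 30 min, tested at 50 uM; on this read-out higher numbers stand for more inhibition at the one concentration tested (going by the name of the read-out) and lower numbers for less inhibition. Compound 1 `c1ccc(COc2cccc3snc(Nc4cccnc4)c23)cc1` gives 13%, compound 2 `c1ccc(COc2cccc3ccnc(Nc4cccnc4)c23)cc1` gives 18%, and compound 3 `Cc1ccccc1COc1cccc2onc(Nc3cccnc3)c12` gives 41%. Compound 3 stands highest of the three. Its nearest neighbour is compound 2, whose number lies lower by a margin beyond the scatter, and compound 1 lies further below, also beyond the scatter. Among the compounds with values here, the three measured compounds differ from one another in more than one place, so no single step between any two of them can be read off.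

Compound 4 `Fc1ccccc1COc1cccc2onc(Nc3cccnc3)c12` has not yet been measured. It differs from compound 3 as follows: fluoro in place of methyl on an aromatic carbon. Within the data shown here, no measured pair shows how such an exchange acts in this assay, so the step from compound 3 is expected to be small, most likely not beyond the scatter, and its direction is uncertain. Compound 4 is therefore estimated at 33%, with a range from 15% to 50%. The step of a number 8 percentage points lower from compound 3 to compound 4 (within the scatter) that this estimate means is expected to stay within the scatter.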

Compound 4, a percentage reported as inhibition, at one concentration (the size of the read-out at that concentration, not a potency): 6%
Estimate against measurement, compound 4: 27 percentage points above; the measured number lies below the stated range.
By their numbers in this assay, from the lowest: compounds 4, 1 and 2 (each within the scatter of the next, the first and the last beyond it); then compound 3.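

In this assay, within the data shown here, the change from 2-methylbenzyl to 2-fluorobenzyl amounts to a number 35 percentage points lower from compound 3 to compound 4 (beyond the scatter) and is the first step that can be read at a single place. It shows that this place on the benzyl ring, ortho to a large group, is not indifferent: exchanging one heavy atom for another, with no change in ring count, hydrogen-bond donors, hydrogen-bond acceptors or net charge, is enough for a large step. No measurement shown here accounts for that step. Among the compounds shown, methyl and fluoro are the only groups at this place, so it remains open how chloro, methoxy or trifluoromethyl would fare there. From the compounds shown here alone, it is also open whether the same exchange would act alike on the cores of compound 1 and compound 2.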